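Carbonyl-side aryl swaps in a cytotoxicity series

The source may report more compounds than this note shows. Statements on the series, on what has been measured and on what is new or still open speak of the compounds shown alone.

Measured so far:
- compound 1, `Cn1cccc1C(=O)/C=C/c1ccc2c(c1)B(O)OC2`: in a functional assay on SK-OV-3 cells (Homo sapiens) for cytotoxicity, read by MTT assay, with a stated time of 48 h (on this read-out higher numbers stand for weaker inhibition and lower numbers for stronger inhibition), compound 1 gives 93600 nM.
- compound 2, `Cc1cccc(C(=O)/C=C/c2ccc3c(c2)B(O)OC3)c1`: in this assay compound 2 gives 2900 nM.

Within the data shown here, compound 2 holds the lower of the two numbers, and the single measured step, a 32-fold lower number from compound 1 to compound 2 (1.51 log units; beyond the scatter), is the only guide available. That step exchanges a five-membered nitrogen-containing ring for a six-membered carbon ring on the carbonyl carbon, so it speaks to the ring type and not to what a phenyl ring carries.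

Compound 3, `O=C(/C=C/c1ccc2c(c1)B(O)OC2)c1ccccc1O`, keeps the six-membered carbon ring of compound 2 and differs only by 2-hydroxyphenyl in place of 3-methylphenyl on a carbonyl carbon. Among the measured compounds shown here, no measured pair shows the effect of exchanging one substituent on a phenyl for another, so the large ring-type step cannot be transferred. The ring class that gave the low number is retained, and the exchange of a methyl for a hydroxyl is expected to move the number little, if at all beyond the scatter, in either direction.

Compound 3 is therefore estimated at 3500 nM in this assay, within 800 nM to 15000 nM, an expected step of a 1.2-fold higher number from compound 2 to compound 3 (0.08 log units; within the scatter).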

Compound 3, half-maximal inhibitory concentration: 48800 nM
Compound 3: middle estimate off by 14-fold (1.14 log units), on the low side; the whole stated range lies below it.
By their numbers in this assay, from the lowest: compound 2; then compounds 3 and 1 (each within the scatter of the next).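

In this assay the six-membered carbon ring alone does not secure the low number: with that ring kept on the carbonyl carbon, 2-hydroxyphenyl in place of 3-methylphenyl gives a large step (a 17-fold higher number from compound 2 to compound 3 (1.23 log units; beyond the scatter)). What the phenyl ring carries therefore matters at this position, which the ring-type step could not show. The step between the other pair (a 1.9-fold lower number from compound 1 to compound 3 (0.28 log units; within the scatter)) lies within the scatter, so the 2-hydroxyphenyl and 1-methyl-1H-pyrrol-2-yl groups cannot be told apart here, and compound 2 alone stands beyond the scatter from both; no measurement bearing on the reason for the large step is available.

The compounds shown leave open whether the step follows the hydroxyl itself or its place on the phenyl ring, a question that 2-methylphenyl and 3-hydroxyphenyl on the carbonyl carbon would separate. They also leave open what a phenyl ring carrying a methoxy group, an amine or a carboxylic acid would give in this assay.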